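The source may hold more compounds than are shown below. What is called first, only, known or untested is meant among the compounds shown, and "the series" means these compounds.

Three compounds of the series share one core and differ only in the group on the benzyl ring. Compound 1 `O=c1c(O)c(-c2ccccc2)oc2cc(OCc3ccccc3Cl)cc(O)c12` carries chloro there. In an ADME assay on Huh-5-2 cells (Homo sapiens) for cytotoxicity, read by WST assay, with a stated time of 3 days (a lower number here means that less compound is tolerated, a higher number that more compound is tolerated), compound 1 gives > 100000 nM, which is a limit of the assay and not a number. Compound 2 `O=c1c(O)c(-c2ccccc2)oc2cc(OCc3ccccc3Br)cc(O)c12` carries bromo. In this assay compound 2 gives > 100000 nM, again a limit. Compound 3 `O=c1c(O)c(-c2ccccc2)oc2cc(OCc3ccccc3[N+](=O)[O-])cc(O)c12` carries nitro. In this assay, for the measured compounds named here, compound 3 gives 32000 nM, the only number in the set. The two other values sit at the limit of > 100000 nM in this assay, at which 2 of the 3 values shown sit. The step that the two limits leave unreadable from compound 1 to compound 2, while an at least 3.1-fold lower number from compound 1 to compound 3 (0.49 log units; beyond the scatter) and an at least 3.1-fold lower number from compound 2 to compound 3 (0.49 log units; beyond the scatter).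

Compound 4 `Cc1ccccc1COc1cc(O)c2c(=O)c(O)c(-c3ccccc3)oc2c1` has not yet been measured in this assay. Its difference from compound 3 is methyl in place of nitro on an aromatic carbon. Both readable steps run toward nitro and lower the number; the change here runs away from nitro. The expected step is a 3.1-fold higher number from compound 3 to compound 4 (0.49 log units; beyond the scatter), carrying the number back toward the limit. The estimate for compound 4 in this assay is 100000 nM, within 40000 nM to 300000 nM.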

Compound 4, half-maximal cytotoxic concentration: 17000 nM
Beside the measured number, compound 4's estimate is 5.9-fold (0.77 log units) above it; the whole stated range lies above it.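

In this assay, nitro and methyl on this aromatic carbon, ortho to a large group, give values within the scatter of each other: a 1.9-fold lower number from compound 3 to compound 4 (0.27 log units; within the scatter). The lower number is therefore not peculiar to nitro, since methyl also separates from both halogens, with bromo replaced in an at least 5.8-fold lower number from compound 2 to compound 4 (0.76 log units; beyond the scatter) and chloro replaced in an at least 5.8-fold lower number from compound 1 to compound 4 (0.76 log units; beyond the scatter). Compound 1 and compound 2 each stand at a limit of the assay and not at a number, so the step between them cannot be read: the limit of > 100000 nM in this assay, at which 2 of the 4 values shown sit.

Open, from the compounds shown here alone, is whether an amine, a carboxylic acid or a methoxy group at this place would fall with nitro and methyl or with chloro and bromo. Also open, going by these compounds, is how far the two halogen compounds actually lie from compound 3 and compound 4, as only minimum sizes can be read for those steps.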